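The source may hold more compounds than are shown below. What is called first, only, known or untested is meant among the compounds shown, and "the series" means these compounds.

Measured compounds:
- compound 1 `O=C(Nc1cc(C(F)(F)F)cc(C(F)(F)F)c1)C1CCc2ccccc2N1C(=O)c1ccccc1Cl` — in a functional assay on NUGC-3 cells (Homo sapiens) for cytotoxicity, read by sulforhodamine B assay, with a stated time of 72 h (on this read-out higher numbers stand for weaker inhibition of growth and lower numbers for stronger inhibition of growth), compound 1 gives 1930 nM
- compound 2 `CC(=O)N1c2ccccc2CCC1C(=O)Nc1ccccc1O` — compound 2 gives 49700 nM
- compound 3 `O=C(Nc1ccccc1O)C1CCc2ccccc2N1C(=O)c1ccccc1Cl` — compound 3 gives 36800 nM

Compound 1 holds the lowest number of the three; compound 3 stands nearest to it and compound 2 furthest, both gaps being beyond the scatter. Among the measured compounds shown here, the one measured step within the set, a 1.4-fold lower number from compound 2 to compound 3 (0.13 log units; within the scatter), concerns the same carbonyl carbon that is varied here and shows that exchanging methyl for 2-chlorophenyl at that place leaves the growth inhibition essentially unchanged.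

Compound 4 `CCCC(=O)N1c2ccccc2CCC1C(=O)Nc1cc(C(F)(F)F)cc(C(F)(F)F)c1` differs from compound 1 by the change (propyl in place of 2-chlorophenyl on a carbonyl carbon). For the measured compounds named here, no measured pair shows propyl at this carbonyl carbon; the closest guide is the methyl-to-2-chlorophenyl step from compound 2 to compound 3, which lay within the scatter. By analogy the aryl group on this carbonyl does not appear to carry much of the activity of compound 1, so a small alkyl in its place is expected to give a number close to that of compound 1, with a modest drift toward weaker growth inhibition allowed for. The expected step is a 1.3-fold higher number from compound 1 to compound 4 (0.13 log units; within the scatter). Compound 4 is therefore estimated at 2600 nM in this assay, with a range from 900 nM to 7500 nM.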

Compound 4, concentration for 50% growth inhibition: 14400 nM
Compound 4: the middle estimate sits 5.5-fold (0.74 log units) below what was measured; the whole stated range lies below it.
By their numbers in this assay, from the lowest: compound 1; then compound 4; then compounds 3 and 2 (each within the scatter of the next).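

In this assay the group on this carbonyl carbon is no longer a silent position: the exchange of 2-chlorophenyl for propyl gives a 7.5-fold higher number from compound 1 to compound 4 (0.87 log units; beyond the scatter) and so moves the number well past the scatter in the setting of compound 1. The earlier step at the same carbon, a 1.4-fold lower number from compound 2 to compound 3 (0.13 log units; within the scatter), had shown nothing of the kind, so across these four compounds the response at this place differs between the two pairs, though the two steps are not the same exchange, as methyl and propyl are different groups and the amide partner on the other side of the shared core differs as well. Nothing measured here bears on why the 2-chlorophenyl group counts in one pair and not in the other.

Still open, from the compounds shown here alone, is whether the difference follows the aromatic ring, its chlorine or the size of the group, which an unsubstituted phenyl, a cyclohexyl or a methyl at this carbonyl carbon in the setting of compound 1 would help to separate. Also open, going by these compounds, is how a longer chain, or one ending in an amine, would read at the same place.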